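Swapping a Bromophenyl for Thiophene on an Aminothiophene Core

This account rests on a few compounds, and the source may have more. Where it says the series, first, only, none or still open, it means among the compounds named here.

Compound 1 `COc1cc(C(=O)c2sc(-c3ccc(Br)cc3)cc2N)cc(OC)c1OC` carries a 4-bromophenyl group on the shared core. In a functional assay on CCRF-CEM cells (Homo sapiens) for antiproliferative activity (a higher number here means a weaker inhibitor, a lower number a stronger inhibitor), compound 1 gives 86 nM, the highest of the three numbers available here. Its nearest neighbour is compound 2 `COc1cc(C(=O)c2sc(-c3ccc(Cl)cc3)cc2N)cc(OC)c1OC`, which in this assay gives 70 nM; the step is a 1.2-fold lower number from compound 1 to compound 2 (0.09 log units; within the scatter), so the two read as equal. Compound 3 `COc1cc(C(=O)c2sc(-c3ccsc3)cc2N)cc(OC)c1OC`, which in this assay gives 9.6 nM, stands furthest away from compound 1, with a 9.0-fold lower number from compound 1 to compound 3 (0.95 log units; beyond the scatter).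

Compound 4 `COc1cc(C(=O)c2sc(-c3cccs3)cc2N)cc(OC)c1OC` has not yet been measured. It differs from compound 1 in one place: thiophen-2-yl in place of 4-bromophenyl on an aromatic carbon. The measured steps that bear on this are those in which a thiophen-3-yl replaced a halogenated phenyl: a 9.0-fold lower number from compound 1 to compound 3 (0.95 log units; beyond the scatter) and a 7.3-fold lower number from compound 2 to compound 3 (0.86 log units; beyond the scatter), both beyond the scatter. Going by the values given here, compound 4 carries a thiophene joined through a different ring carbon, and no measured pair shows what that shift alone does, so the same direction is expected, with less certainty about its size. Compound 4 is therefore expected to give about 15 nM in this assay, with a likely range from 5 nM to 45 nM. This estimate means an expected step of a 5.7-fold lower number from compound 1 to compound 4 (0.76 log units; beyond the scatter), a clear drop in the number.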

Compound 4, half-maximal inhibitory concentration: 9.4 nM
For compound 4 the middle estimate is 1.6-fold (0.20 log units) above the measured one, and the stated range covers the measured number.
By their numbers in this assay, from the lowest: compounds 4 and 3 (each within the scatter of the next); then compounds 2 and 1 (each within the scatter of the next).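

Joining the thiophene to the shared core through a different ring carbon makes no detectable difference in this assay: the change gives a 1.0-fold lower number from compound 3 to compound 4 (0.01 log units; within the scatter), so thiophen-2-yl and thiophen-3-yl read as equal at this position. The lower number seen with thiophen-3-yl is therefore not tied to that one way of joining the ring, since thiophen-2-yl also shows a 9.1-fold lower number from compound 1 to compound 4 (0.96 log units; beyond the scatter) and a 7.4-fold lower number from compound 2 to compound 4 (0.87 log units; beyond the scatter), both beyond the scatter. Among these four compounds, the two thiophenes sit together at the low end and the two halogenated phenyl compounds together at the high end, and no compound goes against this split.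

The compounds shown leave open whether other five-membered rings such as furan-2-yl, a six-membered ring with nitrogen such as pyridin-3-yl, or an unsubstituted phenyl would give numbers like those of the thiophenes or like those of the halogenated phenyls. Nothing available here shows why the thiophenes give the lower numbers, so the difference stands as an observation without an explanation.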